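The source may hold more compounds than are shown below. What is called first, only, known or untested is meant among the compounds shown, and "the series" means these compounds.

Working notes on the series. In a functional assay on K562 cells (Homo sapiens), read by MTT assay, with a stated time of 72 h (a higher number here means a weaker inhibitor, a lower number a stronger inhibitor), compound 1 `Nc1nc(N)c2c(-c3ccco3)cn([C@@H]3O[C@H](CO)[C@@H](O)[C@H]3O)c2n1` reads > 20000 nM as a limit of the assay, not a number. Compound 2 `COc1nc(N)nc2c1c(-c1ccco1)cn2[C@@H]1O[C@H](CO)[C@@H](O)[C@H]1O` reads > 20000 nM as a limit of the assay as well. Both compounds therefore stand at the limit of > 20000 nM in this assay, at which 2 of the 2 values shown sit, and no number is yet in hand.

Compound 3 `COc1nc(N)nc2c1c(-c1cccs1)cn2[C@@H]1O[C@H](CO)[C@@H](O)[C@H]1O` differs from compound 2 on an aromatic carbon of the shared core, with thiophen-2-yl in place of furan-2-yl (thiophen-2-yl in place of furan-2-yl on an aromatic carbon). Among the measured compounds shown here, the only measured step is a step that the two limits leave unreadable from compound 1 to compound 2 and it is methoxy in place of amino on an aromatic carbon. For the measured compounds named here, it has no size to carry over, and no measured step involves furan-2-yl or thiophen-2-yl.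

Because compound 2 sits at the limit > 20000 nM no step beyond the scatter is expected in this assay and another limit is the likeliest report. The expected step is a number no higher from compound 2 to compound 3 (the limit leaves the size open) as a rough estimate only. For compound 3 the estimated value is 20000 nM with an expected range from 5000 nM to 50000 nM on this reasoning.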

Compound 3, half-maximal inhibitory concentration: > 20000 nM
Compound 3: no number, only a limit; the forecaster's own chance of this, stated with the estimate: 75%; the middle value sits exactly at the limit.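

In this assay compound 3 gives > 20000 nM, a limit of the assay and not a number, so no step can be read between compound 2 and compound 3. The compounds shown leave open what size, if any, either change has in this assay, with no number among them: the limit of > 20000 nM in this assay, at which 3 of the 3 values shown sit.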